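Swapping trifluoromethyl for nitro on an aromatic ring

The compounds below may be only part of what the source reports. "The series", "measured", "known", "first", "only" and "open" are said of these compounds alone.

In a functional assay on CaEs17 cells (Homo sapiens) for cytotoxicity, read by MTT assay, with a stated time of 72 h (on this read-out higher numbers stand for weaker inhibition and lower numbers for stronger inhibition), two compounds sharing one core have been measured so far. Compound 1 `C=C1C(=O)[C@@]23C(=O)OC[C@]4(C(=O)CCC(C)(C)[C@H]4C=O)[C@@H]2CC[C@@H]1[C@H]3OC(=O)c1ccc(C)cc1` gives 1050 nM and compound 2 `C=C1C(=O)[C@@]23C(=O)OC[C@]4(C(=O)CCC(C)(C)[C@H]4C=O)[C@@H]2CC[C@@H]1[C@H]3OC(=O)c1ccc(C(F)(F)F)cc1` gives 8960 nM which is the higher of the two numbers and so the weaker inhibition. The next molecule, compound 3 `C=C1C(=O)[C@@]23C(=O)OC[C@]4(C(=O)CCC(C)(C)[C@H]4C=O)[C@@H]2CC[C@@H]1[C@H]3OC(=O)c1ccc([N+](=O)[O-])cc1` keeps that core and changes one group nitro in place of trifluoromethyl on an aromatic carbon with nitro in place of trifluoromethyl on an aromatic carbon, para to a large group. For the measured compounds named here, the only measured step that bears on this is an 8.5-fold higher number from compound 1 to compound 2 (0.93 log units; beyond the scatter) with trifluoromethyl in place of methyl on an aromatic carbon. That modest step lies beyond the scatter and shows that a swap of this group can move the number. Going by the values given here, it gives only indirect guidance, since no measured compound carries nitro. A step of similar or smaller size seems plausible, with a slight lean toward compound 1 at 1050 nM and real doubt about the direction. The expected change is a 1.8-fold lower number from compound 2 to compound 3 (0.25 log units; within the scatter) and remains a rough estimate. For compound 3 the estimated value is 5000 nM with 1500 nM and 15000 nM as the expected ends of the range.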

Compound 3, half-maximal inhibitory concentration: 2680 nM
Compound 3: the middle estimate sits 1.9-fold (0.27 log units) above what was measured; the range from low to high includes it.
By their numbers in this assay, from the lowest: compound 1; then compound 3; then compound 2.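

Replacing trifluoromethyl with nitro on this aromatic carbon in this assay gives a 3.3-fold lower number from compound 2 to compound 3 (0.52 log units; beyond the scatter) and so recovers part of what the earlier swap of methyl for trifluoromethyl had lost. Nitro does not bring the number all the way back, however, as methyl to nitro is a 2.6-fold higher number from compound 1 to compound 3 (0.41 log units; beyond the scatter) and so this position now separates three groups, with methyl giving the lowest number, nitro the middle one and trifluoromethyl the highest, each step lying beyond the usual scatter. Nothing available explains why the three groups fall in this order.

The compounds shown leave open how an amine, a methoxy group or a carboxylic acid on this same aromatic carbon would compare with methyl, and whether any group there could give a lower number than compound 1 does. They also leave open whether the order of methyl, nitro and trifluoromethyl would hold in other cell types, as all of these values come from this assay alone.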